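Side-Chain Exchange at the Ester-Bearing Carbon of Compound 2

The source may hold more compounds than are shown below. What is called first, only, known or untested is meant among the compounds shown, and "the series" means these compounds.

compound 1: `O=C(CN(c1nc(Cl)nc2[nH]cnc12)C1CC1)NCC(=O)OCc1ccccc1` — 21.7%
compound 2: `CC[C@H](C)[C@H](NC(=O)CN(c1nc(Cl)nc2[nH]cnc12)C1CC1)C(=O)OCc1ccccc1` — 22%

In a functional assay on the whole organism (Tail, strain ICR) with Mus musculus as the target, in the tail flick test, with a stated time of 120 min, at a dose of 25 umol/kg by the oral route (a higher number here means a stronger effect of the compound at the dose given, a lower number a weaker effect), compound 1 gives 21.7%, and compound 2 gives 22%. Compound 2 holds the higher of these two numbers, yet a number 0.3 percentage points higher from compound 1 to compound 2 (within the scatter) lies within the scatter, so the two read as equal.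

Compound 3 `CSCC[C@H](NC(=O)CN(c1nc(Cl)nc2[nH]cnc12)C1CC1)C(=O)OCc1ccccc1` differs from compound 2 by 2-(methylsulfanyl)ethyl in place of sec-butyl on a saturated chain carbon bound to an amide-type nitrogen and a carbonyl carbon.

For the measured compounds named here, the only measured step, a number 0.3 percentage points higher from compound 1 to compound 2 (within the scatter), changed the same place and stayed within the scatter; no measured step covers this particular exchange. A change beyond the scatter is therefore not expected. The estimated step is no change at the digits printed from compound 2 to compound 3 (within the scatter). Compound 3 is expected to give 22%, with a range from 10% to 34%.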

Compound 3, a percentage reported as activity, at one dose (the size of the read-out at that dose, not a potency): 31.6%
The estimate for compound 3 lay 9.6 percentage points below the measured number; the measured number falls inside the stated range.
By their numbers in this assay, from the lowest: compounds 1, 2 and 3 (each within the scatter of the next).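

In this assay the exchange of sec-butyl for 2-(methylsulfanyl)ethyl gives a number 9.6 percentage points higher from compound 2 to compound 3 (within the scatter) and the exchange of hydrogen for the same group gives a number 9.9 percentage points higher from compound 1 to compound 3 (within the scatter) so both steps stay within the scatter. This place therefore accepts a sulfur-containing chain with a hydrogen-bond acceptor, and the reading still cannot be told apart from those with sec-butyl or hydrogen. No evidence on the cause of these readings is available.

As far as these compounds go, whether an amine, a carboxylic acid or a longer chain at this carbon would move the reading beyond the scatter remains open.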